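Fluoro step on the benzyl group of compound 2

The compounds below may be only part of what the source reports. "The series", "measured", "known", "first", "only" and "open" are said of these compounds alone.

In a functional assay on HepG2 cells (Homo sapiens) for antiproliferative activity, read by MTT assay, with a stated time of 48 h (on this read-out lower numbers stand for stronger inhibition and higher numbers for weaker inhibition), compound 1 (`O=[N+]([O-])c1cc(C(F)(F)F)cc([N+](=O)[O-])c1Oc1ccc(Cl)cc1/C=N\OCc1ccccc1F`) gives 1020 nM and compound 2 (`O=[N+]([O-])c1cc(C(F)(F)F)cc([N+](=O)[O-])c1Oc1ccc(Br)cc1/C=N\OCc1ccccc1`) gives 1180 nM as its reading, so the two numbers lie within the scatter of each other. Among the compounds with values here, compound 2 therefore stands level with compound 1, the only other measured compound. Within the data shown here, no single-change step between measured compounds is available to size the next change.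

Compound 3 (`O=[N+]([O-])c1cc(C(F)(F)F)cc([N+](=O)[O-])c1Oc1ccc(Br)cc1/C=N\OCc1ccccc1F`) follows from compound 2 by one change, benzyl to 2-fluorobenzyl (fluoro in place of hydrogen on an aromatic carbon): fluoro in place of hydrogen on an aromatic carbon, ortho to a large group. The shared core is otherwise untouched. In this assay no step beyond the scatter is expected, and no firm direction can be assigned. This expectation rests only on the close readings of compound 2 at 1180 nM and compound 1 at 1020 nM in this series. The expected change is a 1.1-fold lower number from compound 2 to compound 3 (0.05 log units; within the scatter) as a central figure, which remains within the scatter. For compound 3 the estimated value is 1050 nM with an expected range from 550 nM to 2000 nM in this assay once measured.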

Compound 3, half-maximal inhibitory concentration: 890 nM
Compound 3: middle estimate off by 1.2-fold (0.07 log units), on the high side; low and high end bracket the measured number.
By their numbers in this assay, from the lowest: compounds 3, 1 and 2 (each within the scatter of the next).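

In this assay, within the data shown here, fluoro in place of hydrogen on an aromatic carbon, ortho to a large group, gives a 1.3-fold lower number from compound 2 to compound 3 (0.12 log units; within the scatter) on the bromo compounds; this is the first sized reading at this position, and benzyl and 2-fluorobenzyl cannot be told apart here. The second step holds 2-fluorobenzyl constant and places bromo in place of chloro on an aromatic carbon, which gives a 1.1-fold lower number from compound 1 to compound 3 (0.06 log units; within the scatter) and shows that this halogen exchange also cannot be told apart from the scatter. With both single changes now sized, neither fluoro on the benzyl group nor the exchange of chloro for bromo separates these compounds in this read-out, and no measurement bearing on the cause of either small step is available.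

Still open, from the compounds shown here alone, is whether a group larger or different in kind from fluoro on this benzyl ring, such as a methoxy group, an amine or a carboxylic acid, would give a step beyond the scatter. Also open, going by these compounds, is whether fluoro at another carbon of that ring, or a longer chain in place of the benzyl group, would change the reading in this assay at all.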